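Methoxy for methyl on the aryl ring of a triazole series

The source may hold more compounds than are shown below. What is called first, only, known or untested is meant among the compounds shown, and "the series" means these compounds.

Compound 1 `CC1(C)[C@H]2CC[C@]1(C)N(Cc1cn(-c3ccc(Cl)cc3)nn1)C(=O)C2` and compound 2 `Cc1ccccc1-n1cc(CN2C(=O)C[C@@H]3CC[C@@]2(C)C3(C)C)nn1` share a bicyclic lactam core linked through a triazole to an aryl group. In a functional assay on LoVo cells (Homo sapiens) for inhibition, read by MTT assay, with a stated time of 24 h (a higher number here means a weaker inhibitor, a lower number a stronger inhibitor), compound 1 gives 160 nM, and compound 2 gives 80 nM. Within the data shown here, the only measured step, a 2.0-fold lower number from compound 1 to compound 2 (0.30 log units; within the scatter), is within the scatter, so the two compounds stand together and neither can be called the more potent on these numbers alone.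

Compound 3 `COc1ccccc1-n1cc(CN2C(=O)C[C@@H]3CC[C@@]2(C)C3(C)C)nn1` differs from compound 2 by methoxy in place of methyl on an aromatic carbon. Among the measured compounds shown here, the one measured step, which exchanged one aryl substituent for another, left this assay essentially unchanged, and it is the only step that bears on the present change. For the measured compounds named here, since the methoxy group enters at the same ring position that the methyl occupied, and since the single comparable exchange moved the number by less than the scatter, he expects the step of a 1.1-fold higher number from compound 2 to compound 3 (0.05 log units; within the scatter) to lie within the scatter as well, with no clear direction. Compound 3 is therefore estimated at 90 nM in this assay, with a range from 30 nM to 270 nM.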

Compound 3, half-maximal inhibitory concentration: 70 nM
Beside the measured number, compound 3's estimate is 1.3-fold (0.11 log units) above it; the measured number falls inside the stated range.
By their numbers in this assay, from the lowest: compounds 3, 2 and 1 (each within the scatter of the next, the first and the last beyond it).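

At this place, on an aromatic carbon ortho to a large group, methoxy brings in one more heavy atom and a hydrogen-bond acceptor, yet a 1.1-fold lower number from compound 2 to compound 3 (0.06 log units; within the scatter) keeps compound 2 and compound 3 together in this assay, so this position takes either group with no readable difference. Among these compounds, the other new step, a 2.3-fold lower number from compound 1 to compound 3 (0.36 log units; beyond the scatter), is the first to lie beyond the scatter, though only modestly, and it separates the 2-methoxyphenyl compound from the 4-chlorophenyl compound in a way the 2-methylphenyl compound could not, while compound 3 still cannot be ranked above compound 2. Nothing measured here accounts for this result.

The compounds shown leave open how far this tolerance extends, for instance whether a hydroxyl group, an amine or a longer ethoxy chain at the same place would also stay level with methyl and methoxy. They also leave open whether the modest separation from compound 1 comes from the group that enters at this place or from the loss of the chlorine, as the two change together in that step.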